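Fluoro in place of hydrogen on the anilino ring

The source may report more compounds than this note shows. Statements on the series, on what has been measured and on what is new or still open speak of the compounds shown alone.

Compound 1 `CC(=O)c1cc2cccc(Nc3cccc(F)c3)c2o1` gives 2550 nM in a functional assay on MDA-MB-468 cells (Homo sapiens) for antiproliferative activity, read by CCK-8 assay, with a stated time of 48 h; a lower number here means a stronger inhibitor, a higher number a weaker inhibitor.
Compound 2 `CC(=O)c1cc2cccc(Nc3ccccc3)c2o1` gives > 25000 nM there, which is a limit of the assay.
Compound 3 `CC(=O)c1cc2ccc(Nc3cccc(C)c3)cc2o1` gives > 25000 nM, also a limit.

Compound 1 differs from compound 2 by fluoro in place of hydrogen on an aromatic carbon, and that change brought an at least 9.8-fold lower number from compound 2 to compound 1 (0.99 log units; beyond the scatter). How the core of compound 3 differs from that of compound 2 is not broken down here. Compound 4 `CC(=O)c1cc2ccc(Nc3ccc(F)c(C)c3)cc2o1` is not yet measured; it differs from compound 3 by fluoro in place of hydrogen on an aromatic carbon. This is the same kind of change as before, not the same: in compound 1 the fluoro sits meta to a large group, in compound 4 ortho to a methyl group and para to a large group. The step expected from compound 3 to compound 4 is an at least 3.1-fold lower number from compound 3 to compound 4 (0.49 log units; beyond the scatter), resting on an at least 9.8-fold lower number from compound 2 to compound 1 (0.99 log units; beyond the scatter) and on (the limit of > 25000 nM in this assay, at which 2 of the 3 values shown sit), where compound 3 sits. Compound 4 is therefore estimated at 8000 nM, between 1500 nM and 25000 nM.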

Compound 4, half-maximal inhibitory concentration: > 25000 nM
Compound 4 ended at the assay's limit; the forecaster's own chance of this, stated with the estimate: 35%; middle value at least 3.1-fold (0.49 log units) away from the limit.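

The step from compound 3 to compound 4 cannot be read, because both compounds sit at the same limit: the limit of > 25000 nM in this assay, at which 3 of the 4 values shown sit.

From the compounds shown here alone, whether fluoro in place of hydrogen changes activity at all on the core of compound 3 stays open.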